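Swapping an aniline-type group for a lactam

This account rests on a few compounds, and the source may have more. Where it says the series, first, only, none or still open, it means among the compounds named here.

compound 1 `Cc1ncccc1-c1cnc(NCc2c(F)ccc3c2CCO3)c2ncc(=O)[nH]c12` gives 21 mL.min-1.g-1
compound 2 `Cc1nc(CN(C)C)ccc1-c1cnc(NCc2c(F)ccc3c2CCO3)c2cn[nH]c(=O)c12` gives 13 mL.min-1.g-1
compound 3 `CN(c1ccccc1)c1cnc(NCc2c(F)ccc3c2CCO3)n2cnnc12` gives 55 mL.min-1.g-1

In an ADME assay on microsomes from liver (Homo sapiens) for metabolic stability, read by LC-MS, using NADPH, with stated times of 5 min and 30 min, tested at 1 uM (a higher number here means faster removal of the compound, a lower number slower removal), compound 3 has the highest number of the three, clearly beyond the usual scatter from both others. Compound 4 `O=C1CCCN1c1cnc(NCc2c(F)ccc3c2CCO3)n2cnnc12` carries 2-oxopyrrolidin-1-yl in place of methyl(phenyl)amino on an aromatic carbon. For the measured compounds named here, no measured pair isolates this change, so the expectation rests on thin evidence. Compound 1 (21 mL.min-1.g-1) and compound 2 (13 mL.min-1.g-1) both lack methyl(phenyl)amino and both sit lower, though their cores differ as well. A downward move beyond the scatter is therefore expected, and the estimated step is a 2.8-fold lower number from compound 3 to compound 4 (0.44 log units; beyond the scatter) in this assay (slower removal). Compound 4 is expected near 20 mL.min-1.g-1 (estimated range 9 mL.min-1.g-1 to 42 mL.min-1.g-1).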

Compound 4, intrinsic clearance in microsomes: < 3 mL.min-1.g-1
Compound 4: a limit, no number; the forecaster's own chance of this, stated with the estimate: 5%; at least 6.6-fold (0.82 log units) between middle value and limit.
By their numbers in this assay, from the lowest: compounds 2 and 1 (each within the scatter of the next); then compound 3. At a limit, below all of these: compound 4.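

In this assay, for the compounds shown here, putting 2-oxopyrrolidin-1-yl in place of methyl(phenyl)amino gives an at least 18-fold lower number from compound 3 to compound 4 (1.26 log units; beyond the scatter), the first pair here that isolates a change at this position. With the core held the same, this one change is enough to produce a large step. Compound 4 reads as a limit of the assay and not as a number, so the step gives only a minimum size: the limit of < 3 mL.min-1.g-1 in this assay, at which 1 of the 4 values shown sits.

From the compounds shown here alone, it remains open whether the step comes from losing the six-membered aromatic ring or from gaining the carbonyl. Pyrrolidin-1-yl, which has the same ring without the carbonyl, would help separate the two.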